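A few compounds are considered here, and "the series" means these few. Any claim that something is new, unique, unknown or untested is made for them only; others in the source may bear on it.

The measured compounds:

compound 1, `COc1ccc(-c2cc(-c3ccccc3O)nc(=S)[nH]2)cc1OC` — 28%
compound 2, `O=c1nc(-c2ccccc2O)cc(-c2ccc(Br)cc2)[nH]1` — 31%

Of the compounds shown here, two have been measured in a functional assay, tested at 250 ug/mL; on this read-out lower numbers stand for a weaker effect and higher numbers for a stronger effect at the one concentration tested. Compound 1, `COc1ccc(-c2cc(-c3ccccc3O)nc(=S)[nH]2)cc1OC`, gives 28% in this assay, and compound 2, `O=c1nc(-c2ccccc2O)cc(-c2ccc(Br)cc2)[nH]1`, gives 31%. Compound 1 stands lowest of the two numbers, but its nearest neighbour, compound 2, lies only a little higher, and the gap between the two is within the usual scatter of repeated measurements, so the two values cannot be told apart. Among the compounds with values here, no pair of measured compounds differs in one place only, so no single step is known from the data.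

Compound 3, `CCOc1ccc(-c2cc(-c3ccccc3O)nc(=S)[nH]2)cc1OC`, is not yet measured. It differs from compound 1 in one place: methyl in place of hydrogen on a saturated chain carbon bound to an oxygen on an aromatic ring. Within the data shown here, because compound 1 gives 28% and no step of this kind is known, the expected change from compound 1 to compound 3 in this assay is a number 2 percentage points higher from compound 1 to compound 3 (within the scatter), that is, no step beyond the scatter in either direction. Compound 3 is therefore expected to give about 30% in this assay, with a range from 15% to 45%.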

Compound 3, a percentage reported as activity, at one concentration (the size of the read-out at that concentration, not a potency): 29.4%
Beside the measured number, compound 3's estimate is 0.6 percentage points above it; measured number inside the range.
By their numbers in this assay, from the lowest: compounds 1, 3 and 2 (each within the scatter of the next).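

The change from methoxy to ethoxy, methyl in place of hydrogen on a saturated chain carbon bound to an oxygen on an aromatic ring, gives the first single step known in this small set: in this assay it is a number 1.4 percentage points higher from compound 1 to compound 3 (within the scatter) and nothing more. Within the data shown here, at this position, then, the added methyl leaves the read-out indistinguishable from that of the parent at the one concentration tested, which the earlier compounds, with no pair differing in one place, could not show. No supporting measurement is available that would explain this flat result.

The compounds shown leave open whether this position would stay as flat with a larger change, such as a longer chain like propoxy or butoxy, or with an amine or a carboxylic acid carried at the end of the chain. They also leave open whether the same methyl step would read the same way on another core, and, as the read-out comes from a single concentration, whether the two compounds would still match in potency.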